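A few compounds are considered here, and "the series" means these few. Any claim that something is new, unique, unknown or untested is made for them only; others in the source may bear on it.

In a functional assay on A-431 cells (Homo sapiens) for inhibition, read by sulforhodamine B assay, with a stated time of 2 days (on this read-out lower numbers stand for stronger inhibition of growth and higher numbers for weaker inhibition of growth), compound 1 `CC1=C(C(=O)Nc2cccc([N+](=O)[O-])c2)C(c2ccc(O)cc2O)NC(Nc2ccc([N+](=O)[O-])cc2Cl)=N1` gives 3940 nM and compound 3 `CC1=C(C(=O)Nc2cccc([N+](=O)[O-])c2)C(c2ccc(O)cc2O)NC(Nc2ccc(S(=O)(=O)Nc3nc(C)cc(C)n3)cc2)=N1` gives the same 3940 nM, while compound 2 `CC1=C(C(=O)Nc2cccc([N+](=O)[O-])c2)C(c2ccc(O)cc2O)NC(Nc2ccc(S(=O)(=O)Nc3ncccn3)cc2)=N1` stands far higher at 69200 nM. Within the data shown here, compound 3 therefore shares the lowest number so far. Compound 4 `CC1=C(C(=O)Nc2cccc([N+](=O)[O-])c2)C(c2ccc(O)cc2O)NC(Nc2ccc(S(=O)(=O)Nc3cc(C)on3)cc2)=N1` changes only the group on the sulfonamide nitrogen: 5-methyl-1,2-oxazol-3-yl in place of 4,6-dimethylpyrimidin-2-yl on a sulfonamide nitrogen. Among the measured compounds shown here, one measured step bears on this site, an 18-fold lower number from compound 2 to compound 3 (1.24 log units; beyond the scatter), when 4,6-dimethylpyrimidin-2-yl replaced pyrimidin-2-yl. The number can clearly move a long way here, but 5-methyl-1,2-oxazol-3-yl has not been tested in this series, so the size of the step is uncertain. A moderate rise in this assay is the expected direction, as a 3.0-fold higher number from compound 3 to compound 4 (0.48 log units; beyond the scatter). For compound 4 the estimated value is 12000 nM, with a range of 3000 nM to 50000 nM.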

Compound 4, concentration for 50% growth inhibition: 2940 nM
Compound 4: the middle estimate sits 4.1-fold (0.61 log units) above what was measured; measured number outside the range, below it.
By their numbers in this assay, from the lowest: compounds 4, 1 and 3 (each within the scatter of the next); then compound 2.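

The step of a 1.3-fold lower number from compound 3 to compound 4 (0.13 log units; within the scatter) shows that, on the sulfonamide nitrogen, a five-membered 5-methyl-1,2-oxazol-3-yl ring and a six-membered 4,6-dimethylpyrimidin-2-yl ring cannot be told apart here. The step of a 24-fold lower number from compound 2 to compound 4 (1.37 log units; beyond the scatter) shows that a second methyl-bearing ring also gives a much lower number than pyrimidin-2-yl does. No data shown explain these results.

From the compounds shown here alone, the separate contributions of the methyl groups and the rings remain open, as does the effect of a phenyl ring or an acetyl group on this nitrogen.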